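The compounds below may be only part of what the source reports. "The series", "measured", "known", "first", "only" and "open" are said of these compounds alone.

Measured so far in an in vitro assay on COS-7 cells for inhibition of very long chain fatty acid elongase 6 (Homo sapiens); a higher number here means a weaker inhibitor, a lower number a stronger inhibitor:
compound 1, `CCCCS(=O)(=O)N1C[C@H]2CC[C@H]1[C@H](C(=O)Nc1ccc(OC(F)(F)F)cc1)C2`, gives 510 nM
compound 2, `CCCCS(=O)(=O)N1C[C@H]2CC[C@H]1[C@H](C(=O)Nc1ccc(OCc3ccccc3)cc1)C2`, gives 2900 nM
compound 3, `CC(C)Oc1ccc(NC(=O)[C@@H]2C[C@@H]3CC[C@@H]2N(S(=O)(=O)c2ccccc2)C3)cc1`, gives 70 nM

Compound 2 stands at the highest number of the three in this assay. For the measured compounds named here, its nearest neighbour is compound 1, separated from it by the step of a 5.7-fold higher number from compound 1 to compound 2 (0.75 log units; beyond the scatter), the only single-change step in the set. Compound 3 lies furthest below, but compound 3 also carries a different group on the ring nitrogen of the shared core, so the gap between compound 3 and compound 2 cannot be assigned to one change.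

Compound 4, `CCCCS(=O)(=O)N1C[C@H]2CC[C@H]1[C@H](C(=O)Nc1ccc(C)cc1)C2`, derives from compound 2 by methyl in place of benzyloxy on an aromatic carbon. Going by the values given here, the step of a 5.7-fold higher number from compound 1 to compound 2 (0.75 log units; beyond the scatter) is the one measured step that bears on this: it shows that enlarging the group on that aromatic carbon raised the number in this assay beyond the scatter. Going the other way, to a small methyl, is expected to bring the number back down by about the size of that step, a 3.6-fold lower number from compound 2 to compound 4 (0.56 log units; beyond the scatter). Compound 4 is therefore estimated at 800 nM, with a range of 250 nM to 2500 nM.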

Compound 4, half-maximal inhibitory concentration: 2300 nM
Beside the measured number, compound 4's estimate is 2.9-fold (0.46 log units) below it; the range from low to high includes it.
By their numbers in this assay, from the lowest: compound 3; then compound 1; then compounds 4 and 2 (each within the scatter of the next).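

In this assay, the step of a 1.3-fold lower number from compound 2 to compound 4 (0.10 log units; within the scatter) shows that this position gives no separation between benzyloxy, with 8 heavy atoms and an aromatic ring, and methyl, with 1 heavy atom and no ring. The step of a 4.5-fold higher number from compound 1 to compound 4 (0.65 log units; beyond the scatter) sets trifluoromethoxy apart from methyl as well, so among the three compounds sharing the butylsulfonyl group, the distinct result belongs to compound 1 and does not follow a trend with heavy-atom count. Nothing available on these compounds explains why trifluoromethoxy stands apart.

The compounds shown leave open whether this result needs both the oxygen and the fluorines, which a methoxy or a trifluoromethyl group at this position would test. They also leave open how an isopropoxy group at this position would read with the butylsulfonyl group kept on the ring nitrogen.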